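Swapping a Ring Amine for a Ring Ether

The compounds below may be only part of what the source reports. "The series", "measured", "known", "first", "only" and "open" are said of these compounds alone.

Compound 2 `CCCCCCCCCCCCCCc1nc(OC2CCC2)nc(N2CCC2)c1O` gives 109% in a functional assay on cells (Lymphocyte, Homo sapiens), read by a luciferase reporter and ATP content, with a stated time of 48 h, tested at 1 uM (on this read-out higher numbers stand for a weaker effect at the one concentration tested and lower numbers for a stronger effect), and stands highest of the three numbers shown, though both others fall within the scatter of it. Compound 1 `CCCCCCCCCCCCCCc1nc(N2CCC2)nc(OC2CCC2)c1O` gives 105% and compound 3 `CCCCCCCCCCCCCCCCc1nc(OC2CCC2)nc(N2CCC2)c1O` gives 102%. Among the compounds with values here, the one measured step, a number 7 percentage points lower from compound 2 to compound 3 (within the scatter), lengthens the chain and moves nothing beyond the scatter. Compound 4 `CCCCCCCCCCCCCCc1nc(OC2CCC2)nc(OC2CCC2)c1O` carries a different change: cyclobutyloxy in place of azetidin-1-yl on an aromatic carbon. Within the data shown here, no measured step touches this swap, so the expectation rests on compound 2 sitting at 109% and on the step of a number 7 percentage points lower from compound 2 to compound 3 (within the scatter) showing no real movement. The step of a number 5 percentage points lower from compound 2 to compound 4 (within the scatter) is therefore expected to stay within the scatter. Compound 4 is estimated at 104%, within 92% to 116%.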

Compound 4, a percentage reported as activity, at one concentration (the size of the read-out at that concentration, not a potency): 99%
Beside the measured number, compound 4's estimate is 5 percentage points above it; measured number inside the range.
By their numbers in this assay, from the lowest: compounds 4, 3, 1 and 2 (each within the scatter of the next).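

In this assay cyclobutyloxy can replace azetidin-1-yl on the aromatic carbon ortho to a hydroxy group with no real movement, a step of a number 10 percentage points lower from compound 2 to compound 4 (within the scatter). With azetidin-1-yl elsewhere on the core, the same swap gives a number 6 percentage points lower from compound 1 to compound 4 (within the scatter), so at both places the read-out tolerates this exchange. Nothing available explains this result. Still open, on these data alone, is whether a dimethylamino group or a carboxylic acid at these places would move the number beyond the scatter.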